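A few compounds are considered here, and "the series" means these few. Any claim that something is new, unique, unknown or untested is made for them only; others in the source may bear on it.

In an ADME assay on PC-3 cells (Homo sapiens) for cytotoxicity, read by WST assay, tested at 100 uM (a higher number here means more inhibition at the concentration tested (going by the name of the read-out), a lower number less inhibition), compound 3 `COC(=O)c1cc(-c2cccc(NC(=O)C3CCCN(C(=O)c4cc(C(F)(F)F)cc(C(F)(F)F)c4)C3)c2)co1` gives 0%. Compound 1 `COC(=O)c1cccc(NC(=O)C2CCCN(C(=O)c3cc(C(F)(F)F)cc(C(F)(F)F)c3)C2)c1` gives 0% and compound 2 `CC(=O)c1cccc(NC(=O)C2CCCN(C(=O)c3cc(C(F)(F)F)cc(C(F)(F)F)c3)C2)c1` gives 0%, and compound 3 stands level with both at the digits shown. Compound 4 `C=CCOc1cccc(NC(=O)C2CCCN(C(=O)c3cc(C(F)(F)F)cc(C(F)(F)F)c3)C2)c1` differs from compound 3 by allyloxy in place of 5-(methoxycarbonyl)furan-3-yl on an aromatic carbon. The measured steps that bear on this change both alter the group on the same aromatic carbon: no change at the digits printed from compound 1 to compound 3 (within the scatter) and no change at the digits printed from compound 2 to compound 3 (within the scatter), while no change at the digits printed from compound 1 to compound 2 (within the scatter) likewise shows nothing beyond the scatter. With no change at the digits printed from compound 1 to compound 3 (within the scatter) and no change at the digits printed from compound 2 to compound 3 (within the scatter) both flat, no step beyond the scatter is expected for compound 4 in this assay, the expected step being no change at the digits printed from compound 3 to compound 4 (within the scatter). Compound 4 is therefore estimated at 0%, with a range from -10% to 15%.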

Compound 4, a percentage reported as inhibition, at one concentration (the size of the read-out at that concentration, not a potency): 0%
The estimate for compound 4 equals the measured number at the digits printed; measured number inside the range.
By their numbers in this assay, from the lowest: compounds 1, 2, 3 and 4 (each within the scatter of the next).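

In this assay the allyloxy group, which has no ring, reads like the three groups before it, with no change at the digits printed from compound 3 to compound 4 (within the scatter) and no change at the digits printed from compound 2 to compound 4 (within the scatter) and no change at the digits printed from compound 1 to compound 4 (within the scatter) in this series. The five-membered aromatic ring of compound 3 is therefore not needed for this flat read-out, and a group with an oxygen attached directly to this aromatic carbon leaves it flat too. Nothing available explains this flat read-out. The compounds shown leave open whether an amine or a carboxylic acid on this carbon would move the read-out, and whether a change elsewhere on the shared core would.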